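Enlarging the Alkyl Group on the Double-Bonded Nitrogen

The source may report more compounds than this note shows. Statements on the series, on what has been measured and on what is new or still open speak of the compounds shown alone.

Compound 1 `CC(C)/N=C(\NC#N)Nc1cccnc1` is the reference point of this small set. In a functional assay on the whole organism (blood, strain Wistar-Okamoto) with Rattus norvegicus as the target, with a stated time of 5 days (a lower number here means that less compound is needed, a higher number that more compound is needed for the effect), compound 1 gives 2.5 mg/kg, the lowest of the three numbers measured, so it needs the least compound for the effect. Two relatives differ from it only at the group on the double-bonded nitrogen. Compound 2 `CCC(CC)/N=C(\NC#N)Nc1cccnc1` carries pentan-3-yl there, and in this assay compound 2 gives 20 mg/kg. Compound 3 `N#CN/C(=N\C1CC1)Nc1cccnc1` carries cyclopropyl, and in this assay compound 3 gives 20 mg/kg. The steps were an 8.0-fold higher number from compound 1 to compound 2 (0.90 log units; beyond the scatter) and an 8.0-fold higher number from compound 1 to compound 3 (0.90 log units; beyond the scatter), while between the two larger groups there was no change at the digits printed from compound 2 to compound 3 (within the scatter).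

Compound 4 `CC(C)CC(C)(C)/N=C(\NC#N)Nc1cccnc1` has not been measured. Its change from compound 1 is isobutyl in place of hydrogen on a saturated chain carbon bound to a double-bonded nitrogen and two saturated chain carbons, so the group on the double-bonded nitrogen becomes larger still. Both measured enlargements of that group raised the number beyond the scatter, and nothing here points the other way. A higher number is therefore expected for compound 4 as well, of roughly the size seen in those two steps, with some room for a larger one. For compound 4 the expected step is an 8.0-fold higher number from compound 1 to compound 4 (0.90 log units; beyond the scatter). Compound 4 is estimated to give 20 mg/kg in this assay, with a range from 5 mg/kg to 80 mg/kg.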

Compound 4, minimum effective dose: 2.5 mg/kg
The estimate for compound 4 lay 8.0-fold (0.90 log units) above the measured number; the measured number lies below the stated range.
By their numbers in this assay, from the lowest: compounds 1 and 4 (each within the scatter of the next); then compounds 2 and 3 (each within the scatter of the next).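

In this assay, putting isobutyl in place of hydrogen on a saturated chain carbon bound to a double-bonded nitrogen and two saturated chain carbons gives no change at the digits printed from compound 1 to compound 4 (within the scatter) and so shows that this position can carry a much larger group with no loss in the dose needed. Enlarging the group therefore does not by itself raise the number, since compound 2 with pentan-3-yl gives 20 mg/kg while compound 4 with its larger group gives 2.5 mg/kg and so breaks the trend that compound 2 and compound 3 had suggested. Nothing shown here explains why particular groups at this position behave so differently.

The compounds shown leave open whether a straight butyl chain or a phenyl ring on the double-bonded nitrogen would match compound 1 or would instead need the higher dose seen for compound 3. They also leave open how a chain ending in a hydroxyl group or an amine would behave at this same position.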